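Amine terminus swap on a chain-substituted core

A few compounds are considered here, and "the series" means these few. Any claim that something is new, unique, unknown or untested is made for them only; others in the source may bear on it.

Measured so far:
compound 1 `CN1CCN(CCCCCCn2c3c(c4ccccc42)C(=O)c2c[n+]([O-])c4ccccc4c2C3=O)CC1` — 3800 nM
compound 2 `O=C1c2c[n+]([O-])c3ccccc3c2C(=O)c2[nH]c3ccccc3c21` — 400 nM
compound 3 `O=C1c2c[n+]([O-])c3ccccc3c2C(=O)c2c1c1ccccc1n2CCCCN1CCNCC1` — 1380 nM

In a toxicity assay on L02 cells (Homo sapiens) for cytotoxicity, read by MTT assay, with a stated time of 72 h (a lower number here means a stronger inhibitor, a higher number a weaker inhibitor), compound 3 stands second highest of the three numbers, between compound 1 and compound 2. Compound 4 `CN(C)CCCCn1c2c(c3ccccc31)C(=O)c1c[n+]([O-])c3ccccc3c1C2=O` differs from compound 3 by dimethylamino in place of piperazin-1-yl on a saturated chain carbon, four bonds along the chain from an aromatic nitrogen. Within the data shown here, no measured step repeats this change exactly. The closest is a 2.8-fold lower number from compound 1 to compound 3 (0.44 log units; beyond the scatter), which also replaced the amine terminus, though together with a different chain length; a 3.5-fold higher number from compound 2 to compound 3 (0.54 log units; beyond the scatter) concerns the chain itself and bears less directly. Both steps were modest, so for compound 4 a modest step or none beyond the scatter is expected in this assay, with the direction uncertain: a 1.1-fold higher number from compound 3 to compound 4 (0.04 log units; within the scatter). Compound 4 is estimated at 1500 nM, within a range from 600 nM to 3500 nM.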

Compound 4, half-maximal inhibitory concentration: 300 nM
Compound 4: the middle estimate sits 5.0-fold (0.70 log units) above what was measured; measured number below the stated range.
By their numbers in this assay, from the lowest: compounds 4 and 2 (each within the scatter of the next); then compound 3; then compound 1.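

In this assay, the amine at the chain end matters by itself at this position: with the butyl chain kept, dimethylamino in place of piperazin-1-yl gives a 4.6-fold lower number from compound 3 to compound 4 (0.66 log units; beyond the scatter) on the same core. The side chain as such need not raise the number, since 4-(dimethylamino)butyl in place of hydrogen on the aromatic nitrogen gives a 1.3-fold lower number from compound 2 to compound 4 (0.12 log units; within the scatter) within the scatter, while a 13-fold lower number from compound 1 to compound 4 (1.10 log units; beyond the scatter) mixes terminus and chain. No measured evidence accounts for these differences. 

Still open, going by these compounds, is whether morpholine or piperidine at the chain end behaves like dimethylamino or like piperazin-1-yl. Also open, on these data alone, is how dimethylamino fares on a shorter or longer chain.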